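A fluoro to chloro swap on compound 3

A few compounds are considered here, and "the series" means these few. Any claim that something is new, unique, unknown or untested is made for them only; others in the source may bear on it.

Measured in a functional assay on HeLa cells (Homo sapiens) for antiproliferative activity, read by MTT assay, with a stated time of 48 h; on this read-out higher numbers stand for weaker inhibition and lower numbers for stronger inhibition:
- compound 1 `Fc1ccc2[nH]c(-c3cn(-c4ccccc4)nc3-c3ccccc3)nc2c1`: 3610 nM
- compound 2 `Cc1ccc2[nH]c(-c3cn(-c4ccccc4)nc3-c3ccc(F)cc3)nc2c1`: 3630 nM
- compound 3 `Cc1cc2nc(-c3cn(-c4ccccc4)nc3-c3ccc(F)cc3)[nH]c2cc1C`: 10200 nM

Of these three, compound 3 stands highest, at 10200 nM. Compound 4 `Cc1cc2nc(-c3cn(-c4ccccc4)nc3-c3ccc(Cl)cc3)[nH]c2cc1C` differs from it in one place: chloro in place of fluoro on an aromatic carbon. This is chloro in place of fluoro on an aromatic carbon, para to a large group. Within the data shown here, only one measured step is available, a 2.8-fold higher number from compound 2 to compound 3 (0.45 log units; beyond the scatter), and this modest step concerns methyl in place of hydrogen, not a halogen. Among the measured compounds shown here, no measured pair exchanges fluoro for chloro, so nothing sets a direction in this assay, and no change beyond the scatter is expected. The expected step is a 1.1-fold lower number from compound 3 to compound 4 (0.05 log units; within the scatter). Compound 4 is estimated at 9000 nM, with an expected range from 3500 nM to 22000 nM.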

Compound 4, half-maximal inhibitory concentration: 21800 nM
Beside the measured number, compound 4's estimate is 2.4-fold (0.38 log units) below it; measured number inside the range.
By their numbers in this assay, from the lowest: compounds 1 and 2 (each within the scatter of the next); then compound 3; then compound 4.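

In this assay the change from 4-fluorophenyl to 4-chlorophenyl gives a 2.1-fold higher number from compound 3 to compound 4 (0.33 log units; beyond the scatter) and is the only halogen exchange among these compounds. It shows that this position, on an aromatic carbon para to a large group, responds to which halogen it carries, here with weaker inhibition for chloro than for fluoro. Nothing available explains this step. As far as these compounds go, whether the same exchange would act alike on compound 2 remains open. So does the effect of a methoxy group or an amine at this position.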